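This account rests on a few compounds, and the source may have more. Where it says the series, first, only, none or still open, it means among the compounds named here.

Measured so far in an ADME assay on PC-3 cells (Homo sapiens) for cytotoxicity, read by WST assay, tested at 100 uM; a higher number here means more inhibition at the concentration tested (going by the name of the read-out), a lower number less inhibition:
- compound 1 `O=C(Nc1ccc(Cl)cc1)C1CCCN(C(=O)c2cccc(-c3ccco3)c2)C1` — 0%
- compound 2 `C=CCOc1cccc(NC(=O)C2CCCN(C(=O)c3cc(C(F)(F)F)cc(C(F)(F)F)c3)C2)c1` — 0%
- compound 3 `Cn1cnnc1-c1cccc(NC(=O)C2CCCN(C(=O)c3cc(C(F)(F)F)cc(C(F)(F)F)c3)C2)c1` — 0%

Compound 1 stands level with compounds 2 and 3 at the digits shown. Its nearest neighbour in the numbers is compound 2, with no change at the digits printed, and its furthest is compound 3, again with no change; all three sit at the same reading within the scatter, so no ordering among them can be drawn. Among the compounds with values here, the one measured step that changes a single place, no change at the digits printed from compound 2 to compound 3 (within the scatter), shows that swapping the group on the anilide side of the shared core leaves the read-out where it was. Compounds 1 and 2 differ in more than one place, and their two values show nothing beyond the same flat reading.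

Compound 4 `CCN(CC)S(=O)(=O)c1cccc(C(=O)N2CCCC(C(=O)Nc3ccc(Cl)cc3)C2)c1` has not been measured. It follows from compound 1 by diethylsulfamoyl in place of furan-2-yl on an aromatic carbon. Within the data shown here, this change sits on the benzoyl side of the core, where no measured step exists, so the measured step bears on it only loosely; that step was flat. With every measured compound at the same reading, a step of no change at the digits printed from compound 1 to compound 4 (within the scatter) is expected, none beyond the scatter. Compound 4 is therefore estimated at 0%, within -8% to 12%.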

Compound 4, a percentage reported as inhibition, at one concentration (the size of the read-out at that concentration, not a potency): 0%
Estimate against measurement, compound 4: no gap at the digits printed, within the range that was stated.
By their numbers in this assay, from the lowest: compounds 1, 2, 3 and 4 (each within the scatter of the next).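

In this assay, within the data shown here, there is no change at the digits printed from compound 1 to compound 4 (within the scatter), and this is the first single-place change read at this aromatic carbon of the six-membered aromatic ring of carbon only, meta to a large group; the earlier step lay elsewhere on the molecule. The exchange is a sizeable one in what can be counted: furan-2-yl, with 5 heavy atoms and a five-membered aromatic ring, leaves, and diethylsulfamoyl, with 8 heavy atoms, no ring and 2 hydrogen-bond acceptors, enters, yet the reading does not move, so the flat picture now reaches both ends of the shared core for the compounds shown. No data are at hand that would explain this flat reading.

As far as these compounds go, whether a primary amine or a carboxylic acid at this aromatic carbon, or a longer chain in place of the ethyl groups on the sulfamoyl nitrogen, would give a different reading remains open. With all the compounds shown at one reading, it is also open whether any group at this position can shift the read-out at all, so the series gives no ranking of groups here.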